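A Methyl on the Ring Nitrogen: Expecting Compound 3

The compounds below may be only part of what the source reports. "The series", "measured", "known", "first", "only" and "open" are said of these compounds alone.

Compound 2 `Cc1n[nH]cc1Nc1nc(N)c2c(C#N)c(N3CCC[C@H]3C)n(C)c2n1` gives 42 nM in an assay on isolated protein for inhibition of Leucine-rich repeat serine/threonine-protein kinase 2 (Homo sapiens), read by TR-FRET and LanthaScreen, with stated times of 50 min and 30 min, in the presence of a further agent that is not named here (on this read-out higher numbers stand for weaker inhibition and lower numbers for stronger inhibition), the lowest of the two numbers shown, with compound 1 `Cc1nn(CC(C)(C)O)cc1Nc1nc(N)c2c(C#N)c(N3CCC[C@H]3C)n(C)c2n1` at 49 nM lying within the scatter of it. Among the compounds with values here, the one measured step bearing on the present change is a 1.2-fold lower number from compound 1 to compound 2 (0.07 log units; within the scatter), hydrogen in place of 2-hydroxy-2-methylpropyl on an aromatic nitrogen. Compound 3 `Cc1nn(C)cc1Nc1nc(N)c2c(C#N)c(N3CCC[C@H]3C)n(C)c2n1` differs from compound 2 by methyl in place of hydrogen on an aromatic nitrogen. On that showing the expected step is a 1.1-fold higher number from compound 2 to compound 3 (0.03 log units; within the scatter), nothing beyond the scatter. Compound 3 is therefore estimated at 45 nM, between 20 nM and 110 nM.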

Compound 3, half-maximal inhibitory concentration: 38 nM
Compound 3: middle estimate off by 1.2-fold (0.07 log units), on the high side; the measured number falls inside the stated range.
By their numbers in this assay, from the lowest: compounds 3, 2 and 1 (each within the scatter of the next).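

In this assay, methyl on the aromatic nitrogen gives a 1.1-fold lower number from compound 2 to compound 3 (0.04 log units; within the scatter), so methyl joins hydrogen and 2-hydroxy-2-methylpropyl as a third group here that moves the number no further than the scatter. Shortening the substituent from 2-hydroxy-2-methylpropyl to methyl gives a 1.3-fold lower number from compound 1 to compound 3 (0.11 log units; within the scatter), again within the scatter, so the hydroxyl-bearing chain is not needed to hold the number in this series. Nothing available accounts for this sameness. Still open, as far as these compounds go, is whether a carboxylic acid, an amine or a longer chain on this nitrogen would also leave the number within the scatter.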